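Swapping the aryl ring on a trimethoxy chalcone

The source may hold more compounds than are shown below. What is called first, only, known or untested is meant among the compounds shown, and "the series" means these compounds.

Three compounds with a shared core have been measured in a functional assay on HCT-116 cells (Homo sapiens) for cytotoxicity, with a stated time of 48 h; on this read-out higher numbers stand for weaker inhibition and lower numbers for stronger inhibition:

Compound 1 `COc1cccc(/C=C/C(=O)c2c(OC)cc(OC)cc2OC)c1` gives 4300 nM.
Compound 2 `COc1cc(OC)c(C(=O)/C=C/c2ccccc2)c(OC)c1` gives 6900 nM.
Compound 3 `COc1cc(OC)c(C(=O)/C=C/c2ccc([N+](=O)[O-])cc2)c(OC)c1` gives 2700 nM.

Compound 1 sits in the middle of these three numbers: compound 3 lies somewhat lower and compound 2 somewhat higher, but both gaps fall within the usual scatter of repeated measurements, so no real order among them can be claimed.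

Compound 4 `COc1cc(OC)c(C(=O)/C=C/c2ccc(F)cc2)c(OC)c1` differs from compound 1 in one place: 4-fluorophenyl in place of 3-methoxyphenyl on a double-bonded chain carbon bound to a double-bonded chain carbon. For the measured compounds named here, two measured steps touch on this change. Taking the methoxy off the aromatic ring gave a 1.6-fold higher number from compound 1 to compound 2 (0.21 log units; within the scatter). Putting a nitro group on the ring gave a 2.6-fold lower number from compound 2 to compound 3 (0.41 log units; beyond the scatter). The move to compound 4 combines a removal like the first with an addition of a different, smaller group in the same kind of position, so the net effect on this assay is expected to be small, perhaps a slight lowering, but probably not beyond the scatter. Compound 4 is therefore estimated at 4500 nM, between 2000 nM and 10000 nM, meaning an expected step of a 1.0-fold higher number from compound 1 to compound 4 (0.02 log units; within the scatter).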

Compound 4, half-maximal inhibitory concentration: 6200 nM
Estimate against measurement, compound 4: 1.4-fold (0.14 log units) below, within the range that was stated.
By their numbers in this assay, from the lowest: compounds 3, 1, 4 and 2 (each within the scatter of the next, the first and the last beyond it).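

In this assay, the fluoro and nitro groups do not read alike on this aromatic carbon: fluoro in place of hydrogen gives a 1.1-fold lower number from compound 2 to compound 4 (0.05 log units; within the scatter), while fluoro in place of nitro gives a 2.3-fold higher number from compound 3 to compound 4 (0.36 log units; beyond the scatter). So the low number of compound 3 does not extend to every group put on the ring, and compound 3 stands apart from compound 4 with only this one group exchanged. The larger swap of 3-methoxyphenyl for 4-fluorophenyl gives a 1.4-fold higher number from compound 1 to compound 4 (0.16 log units; within the scatter), so it shows no real shift, and nothing at hand explains any of these steps.

The case for nitro rests on compound 3 alone. From the compounds shown here alone, whether an amine or a carboxylic acid on the same ring would read like compound 3 or like compound 4 remains open.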